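The compounds below may be only part of what the source reports. "The series", "measured", "known", "first", "only" and "open" are said of these compounds alone.

Compound 2, whose structure is `C=C1CC[C@@H]2[C@](C)(CO)[C@H](OC(C)=O)CC[C@@]2(C)[C@@H]1C/C=C1/C(=O)OC[C@H]1O`, is tested in a functional assay on P388 cells (Mus musculus) for cytotoxicity, read by sulforhodamine B assay (on this read-out higher numbers stand for an effect only at larger amounts of compound and lower numbers for an effect already at smaller amounts), and gives 4.78 uM. This is the higher of the two numbers available, and the gap to the other one lies beyond the usual scatter. Compound 1, with the structure `C=C1CC[C@@H]2[C@](C)(CO[Si](C(C)C)(C(C)C)C(C)C)[C@H](OC(C)=O)CC[C@@]2(C)[C@@H]1C/C=C1/C(=O)OC[C@H]1OC(C)=O`, differs from compound 2 in more than one place; in this assay compound 1 gives 1.41 uM, the lower of the two numbers.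

Compound 3 has the structure `C=C1CC[C@@H]2[C@](C)(CO)[C@H](OC(C)=O)CC[C@@]2(C)[C@@H]1C/C=C1/C(=O)OC[C@H]1OC(C)=O`. It differs from compound 2 in a single place: acetyl in place of hydrogen on an oxygen on a saturated carbon. One of the two changes that separate compound 2 from compound 1 is thus made alone in compound 3, while the rest of compound 2 is kept. Among the compounds with values here, no single-point step between measured compounds is available, so the size of the effect can only be judged from the two values shown.

The change in compound 3 is expected to move the number of compound 2 part of the way toward compound 1, so a step of a 1.8-fold lower number from compound 2 to compound 3 (0.26 log units; within the scatter) is estimated, a moderate lowering rather than none. Compound 3 is therefore expected to give about 2.6 uM in this assay, within a range from 1 uM to 6.5 uM.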

Compound 3, concentration for half-maximal effect: 0.69 uM
Compound 3: the middle estimate sits 3.8-fold (0.58 log units) above what was measured; the whole stated range lies above it.
By their numbers in this assay, from the lowest: compound 3; then compound 1; then compound 2.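

Replacing hydrogen with acetyl on an oxygen on a saturated carbon, the change from hydroxy to acetoxy, proves to matter on its own in this assay (a 6.9-fold lower number from compound 2 to compound 3 (0.84 log units; beyond the scatter)), something the earlier pair could not show, as compound 1 and compound 2 differ in more than one place. The second change, a hydrogen atom in place of the silicon-bearing group on an oxygen on a saturated carbon, also has a measurable effect in this assay (a 2.0-fold lower number from compound 1 to compound 3 (0.31 log units; beyond the scatter)), so removing that large group does not cost activity here, and the two single changes, taken along the path from compound 1 through compound 3 to compound 2, push the number in opposite directions, which the gap between compound 1 and compound 2 alone had hidden. Nothing available offers a reason for either step.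

The compounds shown leave open whether a longer chain on this oxygen, such as a butanoyl ester, or an amine in its place would continue the trend set by acetyl. Within the data shown here, they also leave open whether an acetyl on the other oxygen, the one carrying the silicon-bearing group in compound 1, would act in the same way.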